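Ortho substituent swap on the aryl piperazine: phenyl for trifluoromethoxy

A few compounds are considered here, and "the series" means these few. Any claim that something is new, unique, unknown or untested is made for them only; others in the source may bear on it.

Compound 3 `CN(C)C(=O)c1cccnc1NCCCN1CCN(c2ccccc2OC(F)(F)F)CC1` gives 100 nM in a functional assay on aorta for antagonist activity at Alpha-1D adrenergic receptor (Rattus norvegicus) (a lower number here means tighter binding, a higher number weaker binding), the highest of the three numbers at hand; compound 1 `CN(C)C(=O)c1cccnc1NCCCN1CCN(c2ccccc2C#N)CC1` gives 10 nM and compound 2 `CCOc1ccccc1N1CCN(CCCNc2ncccc2C(=O)N(C)C)CC1` gives 7.94 nM. Compound 4 `CN(C)C(=O)c1cccnc1NCCCN1CCN(c2ccccc2-c2ccccc2)CC1` differs from compound 3 by phenyl in place of trifluoromethoxy on an aromatic carbon. For the measured compounds named here, no measured step exchanges an aromatic substituent for phenyl. The bearing steps are a 10-fold higher number from compound 1 to compound 3 (1.00 log units; beyond the scatter) and a 13-fold higher number from compound 2 to compound 3 (1.10 log units; beyond the scatter), both pointing to the trifluoromethoxy analogue as the weak end of the series. Removing that group is therefore expected to lower the number, though phenyl is unlike cyano or ethoxy, so the estimate is wide: a 3.3-fold lower number from compound 3 to compound 4 (0.52 log units; beyond the scatter). Compound 4 is expected to give 30 nM, within 6 nM to 150 nM.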

Compound 4, dissociation constant: 63.1 nM
The estimate for compound 4 lay 2.1-fold (0.32 log units) below the measured number, and the stated range covers the measured number.
By their numbers in this assay, from the lowest: compounds 2 and 1 (each within the scatter of the next); then compounds 4 and 3 (each within the scatter of the next).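

Phenyl on this aromatic carbon, ortho to a large group, does not separate from trifluoromethoxy, with a 1.6-fold lower number from compound 3 to compound 4 (0.20 log units; within the scatter) as the step between them. Both phenyl and trifluoromethoxy sit apart from the ethoxy and cyano analogues, with a 7.9-fold higher number from compound 2 to compound 4 (0.90 log units; beyond the scatter) and a 6.3-fold higher number from compound 1 to compound 4 (0.80 log units; beyond the scatter) as the steps that place phenyl on the side of the higher numbers, so the four compounds fall into two pairs. Nothing at hand gives a reason for this split.

Open, from the compounds shown here alone, is whether a methoxy or an amine on this carbon would join the ethoxy and cyano pair or the phenyl and trifluoromethoxy pair.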